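Dimethylamino to methylamino: working notes on compound 3

The compounds below may be only part of what the source reports. "The series", "measured", "known", "first", "only" and "open" are said of these compounds alone.

compound 1 `Cc1ccc(S(=O)(=O)Nc2ccc(CNc3nc(N(C)C)nc4ccccc34)cc2)cc1`: 11000 nM
compound 2 `CN(C)c1nc(NCc2ccc(NC(=O)c3ccncc3)cc2)c2ccccc2n1`: 15000 nM

Within the data shown here, in a functional assay on HCT-116 cells (Homo sapiens) for inhibition, read by luminescence and resazurin assay, with a stated time of 3 days (a lower number here means a stronger inhibitor, a higher number a weaker inhibitor), compound 1, at 11000 nM, stands level with compound 2, the only other measured compound. The two lie within the scatter of each other, so neither stands apart.

Still to be measured is compound 3 `CNc1nc(NCc2ccc(NS(=O)(=O)c3ccc(C)cc3)cc2)c2ccccc2n1`, which carries hydrogen in place of methyl on a nitrogen on an aromatic ring. The same difference reads dimethylamino to methylamino.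

Among the measured compounds shown here, the only measured step, a 1.4-fold higher number from compound 1 to compound 2 (0.13 log units; within the scatter), puts (pyridin-4-yl)carbonyl in place of (4-methylphenyl)sulfonyl at a different nitrogen, and it stays within the scatter. That step leaves the dimethylamino group untouched, so no measurement speaks directly to the change at hand. No direction is favoured, and no step beyond the scatter is expected in this assay, though this rests on thin evidence and the range is kept wide.

The estimate for compound 3 is 12000 nM, expected within 4000 nM to 32000 nM. The expected step is a 1.1-fold higher number from compound 1 to compound 3 (0.04 log units; within the scatter).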

Compound 3, half-maximal inhibitory concentration: 5800 nM
The estimate for compound 3 lay 2.1-fold (0.32 log units) above the measured number; measured number inside the range.
By their numbers in this assay, from the lowest: compounds 3, 1 and 2 (each within the scatter of the next, the first and the last beyond it).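

In this assay, among these compounds, the dimethylamino to methylamino change gives a 1.9-fold lower number from compound 1 to compound 3 (0.28 log units; within the scatter) and is the first reading at this position, the earlier step having left the dimethylamino group untouched. With hydrogen in place of methyl on a nitrogen on an aromatic ring, the one carbon that leaves does not take the number outside the scatter, so this single change shows no measurable dependence on that methyl in this assay. No evidence on the cells or on the compounds bears on this reading, and it stands as a bare comparison of one pair.

Open, from the compounds shown here alone, is whether a plain amine, with both methyl groups gone, or an ethyl or longer chain on this nitrogen would also stay within the scatter of compound 1 or would move beyond it. Also open, going by these compounds, is whether hydrogen in place of methyl at this position gives a comparable step when the (pyridin-4-yl)carbonyl group of compound 2 stands in place of the (4-methylphenyl)sulfonyl group.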